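A few compounds are considered here, and "the series" means these few. Any claim that something is new, unique, unknown or untested is made for them only; others in the source may bear on it.

Compound 1 `COc1ccc(C(=O)/C=C/c2cc(-c3cc(OC)c(OC)c(OC)c3)n3nc(-c4ccccc4)cc3n2)cc1` gives 13200 nM in a functional assay on MDA-MB-231 cells (Homo sapiens) for antiproliferative activity, read by MTT assay, with a stated time of 24 h (on this read-out lower numbers stand for stronger inhibition and higher numbers for weaker inhibition), and holds the lowest of the two numbers recorded; its nearest neighbour is compound 2 `COc1cc(C(=O)/C=C/c2cc(-c3cc(OC)c(OC)c(OC)c3)n3nc(-c4ccccc4)cc3n2)cc(OC)c1OC`, which gives 24300 nM in this assay, and the step of a 1.8-fold higher number from compound 1 to compound 2 (0.27 log units; within the scatter) stays within the scatter. Compound 3 `COc1cc(-c2cc(C(=O)/C=C/c3ccccc3)nc3cc(-c4ccccc4)nn23)cc(OC)c1OC` differs from compound 1 by (2-phenylethenyl)carbonyl in place of 2-((4-methoxyphenyl)carbonyl)ethenyl on an aromatic carbon. For the measured compounds named here, only one measured step exists, and it concerns the aryl group on the carbonyl rather than the orientation of the enone, so it bears on the change only indirectly; its size, a 1.8-fold higher number from compound 1 to compound 2 (0.27 log units; within the scatter), shows that altering the chalcone part moved the read-out little. Without a closer precedent, the expected step in this assay, a 1.1-fold higher number from compound 1 to compound 3 (0.06 log units; within the scatter), is taken as no change beyond the scatter. Compound 3 is therefore estimated to give 15000 nM in this assay, within a range from 5000 nM to 45000 nM.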

Compound 3, half-maximal inhibitory concentration: 19200 nM
Beside the measured number, compound 3's estimate is 1.3-fold (0.11 log units) below it; low and high end bracket the measured number.
By their numbers in this assay, from the lowest: compounds 1, 3 and 2 (each within the scatter of the next).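

In this assay, putting (2-phenylethenyl)carbonyl in place of 2-((4-methoxyphenyl)carbonyl)ethenyl on this aromatic carbon gives a 1.5-fold higher number from compound 1 to compound 3 (0.16 log units; within the scatter), so the read-out does not separate the two groups. The earlier step altered only the aryl group on the carbonyl, whereas this one changes the group attached directly to the shared core, and it too stays within the scatter. Nothing measured here bears on why the number stays within the scatter after this change.

This single step combines the different arrangement of the chain with the loss of the methoxy group, so it cannot show what each contributes alone. On these data alone, whether an amine, a carboxylic acid or a longer saturated chain on this aromatic carbon would move the number beyond the scatter remains open.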